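The source may hold more compounds than are shown below. What is called first, only, known or untested is meant among the compounds shown, and "the series" means these compounds.

Working notes on the series.

Compound 2 `C[C@@H]1CCCN1c1[nH]c2ncnc(N)c2c1C#N` is the unsubstituted parent of the set; in an assay on isolated protein for inhibition of Leucine-rich repeat serine/threonine-protein kinase 2 variant G2019S (Homo sapiens), read by TR-FRET and LanthaScreen, with stated times of 50 min and 30 min, in the presence of a further agent that is not named here (on this read-out higher numbers stand for weaker inhibition and lower numbers for stronger inhibition), compound 2 gives 201 nM. Compound 1 `C[C@@H]1CCCN1c1c(C#N)c2c(N)ncnc2n1C` carries the change methyl in place of hydrogen on an aromatic nitrogen on the core; in this assay compound 1 gives 11 nM, and the step is an 18-fold lower number from compound 2 to compound 1 (1.26 log units; beyond the scatter). Compound 3 `Cc1n[nH]cc1Nc1nc(N)c2c(C#N)c(N3CCC[C@H]3C)n(C)c2n1` adds a (3-methyl-1H-pyrazol-4-yl)amino group to compound 1; in this assay compound 3 gives 27 nM, with the step of a 2.5-fold higher number from compound 1 to compound 3 (0.39 log units; beyond the scatter). The difference between the core of compound 2 and the core of compound 3 is not broken down here; their values alone show compound 3 with the lower number.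

Compound 4 `Cc1nn(C)cc1Nc1nc(N)c2c(C#N)c(N3CCC[C@H]3C)n(C)c2n1` is not yet measured. It differs from compound 3 by methyl in place of hydrogen on an aromatic nitrogen. Among the compounds with values here, this is the same kind of change as the one from compound 2 to compound 1, but the surroundings differ: there the methyl went onto an aromatic nitrogen of a five-membered aromatic ring with 1 nitrogen, part of a fused or bridged system of two rings, next to the ring atom that bears a 2-methylpyrrolidin-1-yl group; here it goes onto an aromatic nitrogen of a five-membered aromatic ring with 2 nitrogen, next to the ring nitrogen and two ring bonds from the ring atom that bears a methyl group. Within the data shown here, the earlier step was large, but only one example exists and it sits on a different ring, so a smaller effect is expected for compound 4 in this assay, namely a 1.4-fold lower number from compound 3 to compound 4 (0.13 log units; within the scatter), resting on the direction of an 18-fold lower number from compound 2 to compound 1 (1.26 log units; beyond the scatter) rather than its size. The estimated value for compound 4 is 20 nM, expected to fall between 6 nM and 70 nM.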

Compound 4, half-maximal inhibitory concentration: 30 nM
Compound 4: the middle estimate sits 1.5-fold (0.18 log units) below what was measured; the range from low to high includes it.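

In this assay, methyl in place of hydrogen on an aromatic nitrogen does not carry over as a fixed step from one core to the other: the same change on two cores in this assay, an 18-fold lower number (1.26 log units; beyond the scatter) from compound 2 to compound 1 and a 1.1-fold higher number (0.05 log units; within the scatter) from compound 3 to compound 4, 20-fold (1.31 log units) apart, beyond the scatter of two such steps

The new step, a 1.1-fold higher number from compound 3 to compound 4 (0.05 log units; within the scatter), lies within the scatter, so compound 3 and compound 4 cannot be told apart here, and the (1,3-dimethyl-1H-pyrazol-4-yl)amino group keeps the number close to that of its (3-methyl-1H-pyrazol-4-yl)amino counterpart, with a 2.7-fold higher number from compound 1 to compound 4 (0.44 log units; beyond the scatter) as a modest step. Within the data shown here, this does not show what sets the size of the step, since the two examples place the methyl on different rings and in different surroundings, and with only one pair on each ring the contribution of the ring cannot be separated from that of the rest of the molecule.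

The compounds shown leave open how the number responds to anything larger than methyl on the aromatic nitrogen of the five-membered ring with 2 nitrogen, such as an ethyl group or a longer chain ending in an amine or a carboxylic acid. Also open, from the compounds shown here alone, is whether the methyl on the aromatic nitrogen of the core still counts for as much once the (3-methyl-1H-pyrazol-4-yl)amino group is present.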